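Series notes: three bromo analogues at the assay limit

A few compounds are considered here, and "the series" means these few. Any claim that something is new, unique, unknown or untested is made for them only; others in the source may bear on it.

Compound 1 `COc1c(Br)cc(Br)cc1C(=O)Nc1ccccc1`, compound 2 `COc1c(Br)cccc1C(=O)Nc1ccccc1` and compound 3 `O=C(Nc1ccccc1)c1cccc(Br)c1` have been run in an assay for inhibition of HSP60/HSP10 (Homo sapiens), with a stated time of 60 min; a lower number here means a stronger inhibitor, a higher number a weaker inhibitor. Compound 1 gives > 100000 nM, which is a limit of this assay and not a number. Compound 2 gives > 100000 nM, likewise a limit. Compound 3 gives > 100000 nM, again a limit. Hence a step that the two limits leave unreadable from compound 2 to compound 1 and a step that the two limits leave unreadable from compound 2 to compound 3 cannot be sized; all three values sit at the limit of > 100000 nM in this assay, at which 3 of the 3 values shown sit.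

Compound 4 `O=C(Nc1ccccc1)c1cc(Br)cc(Br)c1` has not been measured. Its difference from compound 3 is bromo in place of hydrogen on an aromatic carbon. The change from compound 2 to compound 1, (bromo in place of hydrogen on an aromatic carbon), is the same kind of change, but there the place is also para to a methoxy group, which is absent around the place in compound 4. The two cores differ by hydrogen in place of methoxy on an aromatic carbon. For this assay a step that the limit leaves unreadable from compound 3 to compound 4 is expected, of no better readable size than the earlier one, since compound 2 and compound 1 both sit at the limit of > 100000 nM in this assay, at which 3 of the 3 values shown sit. Compound 4 is expected to give 200000 nM, within a range from 60000 nM to 1000000 nM, most probably reported only as a limit.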

Compound 4, half-maximal inhibitory concentration: > 100000 nM
Compound 4: a limit, no number; the forecaster's own chance of this, stated with the estimate: 85%; the middle value lies beyond the limit too.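

No step can be read from compound 3 to compound 4 or from compound 1 to compound 4, because each pair has a limit at both ends and no number in this assay: the limit of > 100000 nM in this assay, at which 4 of the 4 values shown sit.

The compounds shown leave open whether bromo or methoxy on the shared core changes inhibition at all, since none of them gives a number.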